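Changing the Acyl Group from Compound 3 to Compound 4

The source may hold more compounds than are shown below. What is called first, only, known or untested is meant among the compounds shown, and "the series" means these compounds.

Measured in a functional assay on NCI-H1975 cells (Homo sapiens) for antiproliferative activity; a higher number here means a weaker inhibitor, a lower number a stronger inhibitor:
- compound 1 `Cc1c2c(n3c1CCNC[C@@H](C)[C@H](C)Nc1cc-3ccc1C(N)=O)CC(C)(C)CC2=O`: 27 nM
- compound 2 `CC(=O)N1CCc2c(C)c3c(n2-c2ccc(C(N)=O)c(c2)N[C@@H](C)[C@H](C)C1)CC(C)(C)CC3=O`: 15 nM
- compound 3 `COCCC(=O)N1CCc2c(C)c3c(n2-c2ccc(C(N)=O)c(c2)N[C@@H](C)[C@H](C)C1)CC(C)(C)CC3=O`: 31 nM

Compound 3 stands within the scatter of compound 1 but apart from compound 2. Compound 4 `CC[C@H](N)C(=O)N1CCc2c(C)c3c(n2-c2ccc(C(N)=O)c(c2)N[C@@H](C)[C@H](C)C1)CC(C)(C)CC3=O` carries 1-aminopropyl in place of 2-methoxyethyl on a carbonyl carbon. Going by the values given here, no measured step makes this exact exchange. The nearest evidence comes from changes on the amine nitrogen in a ring, with a 1.8-fold lower number from compound 1 to compound 2 (0.26 log units; within the scatter) and a 1.1-fold higher number from compound 1 to compound 3 (0.06 log units; within the scatter), both within the scatter. The step in the acyl chain itself is modest, with a 2.1-fold higher number from compound 2 to compound 3 (0.32 log units; beyond the scatter). A change beyond the scatter is therefore not expected in this assay, and the estimated step is a 1.2-fold lower number from compound 3 to compound 4 (0.09 log units; within the scatter). The estimate for compound 4 is 25 nM, with an expected range from 10 nM to 65 nM.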

Compound 4, half-maximal inhibitory concentration: 41 nM
Compound 4: middle estimate off by 1.6-fold (0.21 log units), on the low side, within the range that was stated.
By their numbers in this assay, from the lowest: compounds 2, 1, 3 and 4 (each within the scatter of the next, the first and the last beyond it).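

In this assay the exchange of 2-methoxyethyl for 1-aminopropyl on the carbonyl carbon brings in a hydrogen-bond donor and a defined stereocentre, yet the step stays within the scatter (a 1.3-fold higher number from compound 3 to compound 4 (0.12 log units; within the scatter)). Measured against the methyl of compound 2, however, 1-aminopropyl gives a step beyond the scatter (a 2.7-fold higher number from compound 2 to compound 4 (0.44 log units; beyond the scatter)), while the full acyl group on the ring nitrogen stays within it (a 1.5-fold higher number from compound 1 to compound 4 (0.18 log units; within the scatter)). Nothing given here explains these steps. The compounds shown leave open how the opposite stereoisomer of 1-aminopropyl would read, or a carboxylic acid in place of its amine.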